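Cytotoxicity on Vero cells: methoxy to trifluoromethoxy

This account rests on a few compounds, and the source may have more. Where it says the series, first, only, none or still open, it means among the compounds named here.

Measured so far in an ADME assay on Vero cells (Chlorocebus sabaeus) for cytotoxicity, read by resazurin assay, with a stated time of 3 days; a lower number here means a stronger inhibitor, a higher number a weaker inhibitor:
- compound 1 `COc1ccc(C(=O)Nc2cc3nc(C4CCCCC4)[nH]c3cc2N(C)C)cc1`: > 100 ug/mL
- compound 2 `COc1ccc(C(=O)Nc2cc3nc(C4CCCCC4)[nH]c3cc2N2CCCC2)cc1`: > 100 ug/mL
- compound 3 `CCCCCC(=O)Nc1cc2nc(C3CCCCC3)[nH]c2cc1N(C)C`: > 100 ug/mL

Compound 1 `COc1ccc(C(=O)Nc2cc3nc(C4CCCCC4)[nH]c3cc2N(C)C)cc1` stands only at a limit of the assay, with no number of its own. Compound 2 `COc1ccc(C(=O)Nc2cc3nc(C4CCCCC4)[nH]c3cc2N2CCCC2)cc1` likewise gives only a limit. Compound 3 `CCCCCC(=O)Nc1cc2nc(C3CCCCC3)[nH]c2cc1N(C)C` also gives only a limit. The two measured steps, a step that the two limits leave unreadable from compound 1 to compound 2 and a step that the two limits leave unreadable from compound 1 to compound 3, cannot be read in size because of the limit of > 100 ug/mL in this assay, at which 3 of the 3 values shown sit.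

Compound 4 `CN(C)c1cc2[nH]c(C3CCCCC3)nc2cc1NC(=O)c1ccc(OC(F)(F)F)cc1` differs from compound 1 by trifluoromethyl in place of methyl on an oxygen on an aromatic ring. The step from compound 1 to compound 3 touches the same part of the molecule, the group on the carbonyl carbon, but its size is not readable. Neither measured step therefore gives a direction or a size to expect here, and the most that the three values together suggest is that the series so far has not shown a readable number in this assay.

Compound 4 is thus expected to sit near 100 ug/mL (range 50 ug/mL to 200 ug/mL), most likely again as a limit. The estimated step, a number no higher from compound 1 to compound 4 (the limit leaves the size open), is accordingly expected to be none beyond the scatter.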

Compound 4, half-maximal inhibitory concentration: > 100 ug/mL
Compound 4 gave a limit, no number (the forecaster's own chance of this, stated with the estimate: 80%); the middle value lies on the limit itself.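

Compound 1 and compound 4 each give only a limit in this assay, so the step from methoxy to trifluoromethoxy cannot be read in size: the limit of > 100 ug/mL in this assay, at which 4 of the 4 values shown sit.

The compounds shown leave open what number any of them would give in this assay, and whether trifluoromethyl in place of methyl shifts it at all.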